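The compounds below may be only part of what the source reports. "The series", "measured", "known", "first", "only" and "open" are said of these compounds alone.

Measured so far in a functional assay on DU-145 cells (Homo sapiens) for antiproliferative activity, read by MTT assay, with a stated time of 48 h; a lower number here means a stronger inhibitor, a higher number a weaker inhibitor:
Compound 1 `C/C(=C\CC/C(C)=C/CC[C@@H]1[C@@]2(C)CCC(=O)C(C)(C)[C@H]2CC[C@@]1(C)O)CC/C=C(\C)C(=O)OCc1cn(-c2ccccc2)nn1` gives 95500 nM.
Compound 2 `C/C(=C\CC/C(C)=C/CC[C@@H]1[C@@]2(C)CCC(=O)C(C)(C)[C@H]2CC[C@@]1(C)O)CC/C=C(\C)C(=O)OCc1cn(-c2ccc(Br)cc2)nn1` reaches only a limit of the assay, > 150000 nM.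
Compound 3 `C/C(=C\CC/C(C)=C/CC[C@@H]1[C@@]2(C)CCC(=O)C(C)(C)[C@H]2CC[C@@]1(C)O)CC/C=C(\C)C(=O)OCc1cn(-c2ccc(C(C)(C)C)cc2)nn1` likewise reaches only a limit of the assay, > 150000 nM.

Compound 3 thus sits at the edge of what this assay can report, a point shared by a second compound (the limit of > 150000 nM in this assay, at which 2 of the 3 values shown sit). Compound 4 `C/C(=C\CC/C(C)=C/CC[C@@H]1[C@@]2(C)CCC(=O)C(C)(C)[C@H]2CC[C@@]1(C)O)CC/C=C(\C)C(=O)OCc1cn(-c2ccc(C)cc2)nn1` differs from it by methyl in place of tert-butyl on an aromatic carbon. The step that bears on this is the one bringing in tert-butyl, an at least 1.5-fold higher number from compound 1 to compound 3 (0.19 log units; that floor lies within the scatter); the bromo step an at least 1.5-fold higher number from compound 1 to compound 2 (0.19 log units; that floor lies within the scatter) points the same way. Methyl in place of tert-butyl may undo part of that rise, so a somewhat lower number is expected, an at least 1.2-fold lower number from compound 3 to compound 4 (0.09 log units; that floor lies within the scatter), though the floor of that earlier step lies within the scatter. Compound 4 is therefore estimated at 120000 nM, between 60000 nM and 200000 nM.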

Compound 4, half-maximal inhibitory concentration: > 150000 nM
Compound 4 was reported as a limit; the forecaster's own chance of this, stated with the estimate: 40%; middle value at least 1.2-fold (0.09 log units) from the limit.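

Even methyl, a single carbon in place of the four of tert-butyl, leaves compound 4 at a limit of this assay, > 150000 nM. Going by these compounds alone, the one step that can be read is an at least 1.5-fold higher number from compound 1 to compound 4 (0.19 log units; that floor lies within the scatter). The steps among compounds 2, 3 and 4 cannot be read, and only compound 1 gives a number rather than a limit: the limit of > 150000 nM in this assay, at which 3 of the 4 values shown sit.

On these data alone, how compounds 2, 3 and 4 rank among themselves stays open. So does whether an amine or a carboxylic acid at this place on the aromatic ring would give a readable value.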